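The compounds below may be only part of what the source reports. "The series", "measured", "known", "first", "only" and "open" are said of these compounds alone.

Three compounds share one core and differ only in the substituent pattern on a phenyl ring. Compound 1 `Cc1nc(-c2ccccc2)sc1COc1ccc2c(c1)OCC2CC(=O)O` gives, in a functional assay on CHO cells for agonist activity at Free fatty acid receptor 1 (Homo sapiens), read by FLIPR and calcium flux, tested at 100 nM (a lower number here means a weaker effect, a higher number a stronger effect of the compound at the concentration tested), a read-out of 54.8%. Compound 2 `Cc1ccccc1-c1nc(C)c(COc2ccc3c(c2)OCC3CC(=O)O)s1` gives 10.7% in this assay, and compound 3 `Cc1ccc(-c2nc(C)c(COc3ccc4c(c3)OCC4CC(=O)O)s2)cc1` gives 54.9%. Compound 3 and compound 1 cannot be told apart, since a number 0.1 percentage points higher from compound 1 to compound 3 (within the scatter). Compound 2 sits far below both: a number 44.1 percentage points lower from compound 1 to compound 2 (beyond the scatter), and a number 44.2 percentage points higher from compound 2 to compound 3 (beyond the scatter).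

Compound 4 `Cc1nc(-c2ccc(Cl)cc2)sc1COc1ccc2c(c1)OCC2CC(=O)O` is the next step from compound 3: chloro in place of methyl on an aromatic carbon. Within the data shown here, the step that bears most directly on this is the one from compound 1 to compound 3, where a methyl entered at the same place on the six-membered aromatic ring of carbon only and the read-out stayed put within the scatter. The two large steps involve 2-methylphenyl and do not speak to this position. Among the measured compounds shown here, no measured pair shows chloro replacing methyl. The expectation is therefore a step of about a number 0.1 percentage points higher from compound 3 to compound 4 (within the scatter) in this assay, that is, none beyond the scatter, with the uncertainty of an untested group. Compound 4 is estimated at 55%, within 35% to 75%.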

Compound 4, a percentage reported as activity, at one concentration (the size of the read-out at that concentration, not a potency): 53.4%
Compound 4: the middle estimate sits 1.6 percentage points above what was measured; the measured number falls inside the stated range.
By their numbers in this assay, from the lowest: compound 2; then compounds 4, 1 and 3 (each within the scatter of the next).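

At the place para to a large group on the six-membered aromatic ring, the compounds shown now give the same read-out with three different groups in this assay: chloro cannot be told from methyl (a number 1.5 percentage points lower from compound 3 to compound 4 (within the scatter)) or from hydrogen (a number 1.4 percentage points lower from compound 1 to compound 4 (within the scatter)). Among these compounds, until now only methyl had been compared with hydrogen here, so this tolerance rested on a single change. 4-Chlorophenyl also stands clearly apart from 2-methylphenyl (a number 42.7 percentage points higher from compound 2 to compound 4 (beyond the scatter)), so compound 2 remains the only low compound of the four, and no measurement at hand explains either the flat result or that gap.

On these data alone, whether this tolerance extends to an amine, a carboxylic acid or a longer chain such as butyl at the same place remains open. So does whether 2-chlorophenyl would behave like 2-methylphenyl.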